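The source may hold more compounds than are shown below. What is called first, only, known or untested is meant among the compounds shown, and "the series" means these compounds.

Compound 1 `COc1ccc(-c2cc(/C=C/C(=O)c3ccc(C)cc3)nc3cc(-c4ccccc4)nn23)cc1OC`, compound 2 `COc1ccc(-c2cc(/C=C/C(=O)c3ccc(C)c(C)c3)nc3cc(-c4ccccc4)nn23)cc1OC` and compound 3 `COc1cc(-c2cc(/C=C/C(=O)c3ccc(C)cc3)nc3cc(-c4ccccc4)nn23)cc(OC)c1OC` have been measured in an ADME assay on HEK293 cells (Homo sapiens) for antiproliferative activity, read by MTT assay, with a stated time of 24 h; a lower number here means a stronger inhibitor, a higher number a weaker inhibitor. Compound 1 gives 62600 nM, compound 2 gives 46200 nM and compound 3 gives 50400 nM. The change hydrogen in place of methyl on an aromatic carbon produced a 1.4-fold higher number from compound 2 to compound 1 (0.13 log units; within the scatter). Compound 4 `COc1cc(-c2cc(/C=C/C(=O)c3ccccc3)nc3cc(-c4ccccc4)nn23)cc(OC)c1OC` has not yet been measured; it arises from compound 3 by hydrogen in place of methyl on an aromatic carbon. This is the same kind of change as that from compound 2 to compound 1, but not the same one: there the place was ortho to a methyl group and meta to a large group, here it is para to a large group. The difference between the cores of compound 2 and compound 3 is not broken down here. Because the earlier step of a 1.4-fold higher number from compound 2 to compound 1 (0.13 log units; within the scatter) stayed within the scatter, compound 4 is expected to show a step of similar size, a 1.2-fold higher number from compound 3 to compound 4 (0.08 log units; within the scatter). Compound 4 is accordingly estimated at 60000 nM, with a range from 30000 nM to 120000 nM.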

Compound 4, half-maximal inhibitory concentration: >= 100000 nM
Compound 4 gave a limit, no number (the forecaster's own chance of this, stated with the estimate: 10%); middle value at least 1.6-fold (0.22 log units) from the limit.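

In this assay compound 4 gives >= 100000 nM, which is a limit of the assay and not a number. From the compounds shown here alone, replacing 4-methylphenyl with phenyl on the core of compound 3 therefore gives only a floor for the step, an at least 1.9-fold higher number from compound 3 to compound 4 (0.29 log units; that floor lies within the scatter), and its true size stays unknown. This shows that the change does not lower the number on either core, but it does not show whether the step carries over at the same size: the same change on two cores in this assay, a 1.4-fold higher number (0.13 log units; within the scatter) from compound 2 to compound 1 and an at least 1.9-fold higher number (0.29 log units; that floor lies within the scatter) from compound 3 to compound 4; the limit leaves it open whether they differ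

The compounds shown leave open what an amine or a carboxylic acid in place of that methyl would do in this assay. They also leave open whether a longer chain at that place would give a value that can be read as a number on either core.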